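Amine-side aryl swap in the diaryl ether series

The source may report more compounds than this note shows. Statements on the series, on what has been measured and on what is new or still open speak of the compounds shown alone.

Compound 2 `COc1ccc(CCCNCc2c(OC)cc(Oc3cccc(Nc4ccccc4)c3)cc2OC)cc1` gives 6400 nM in a functional assay on SW-620 cells (Homo sapiens) for inhibition, read by MTT assay, with a stated time of 72 h; on this read-out higher numbers stand for weaker inhibition and lower numbers for stronger inhibition. Compound 2 holds the highest of the two numbers seen so far, though compound 1 `COc1cc(Oc2cccc(Nc3ccccc3)c2)cc(OC)c1CNCc1ccc(Cl)cc1`, which gives 6340 nM, sits within the scatter of it. The next member, compound 3 `COc1cc(Oc2cccc(Nc3ccccc3)c2)cc(OC)c1CNCc1ccc(O)cc1`, changes the group on a saturated chain carbon bound to an amine nitrogen: 4-hydroxyphenyl in place of 2-(4-methoxyphenyl)ethyl on a saturated chain carbon bound to an amine nitrogen. For the measured compounds named here, the one measured step at the same place, a 1.0-fold higher number from compound 1 to compound 2 (0.00 log units; within the scatter), was flat. That earlier exchange of aryl groups at the same carbon left the number unchanged, and no step beyond the scatter is expected here either; the direction is open, and a small drift either way would not be told apart from repeat variation. For compound 3 the expected step is no change at the digits printed from compound 2 to compound 3 (within the scatter). Compound 3 is therefore estimated at 6400 nM, with a range from 3000 nM to 14000 nM.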

Compound 3, half-maximal inhibitory concentration: 7940 nM
For compound 3 the middle estimate is 1.2-fold (0.09 log units) below the measured one; measured number inside the range.
By their numbers in this assay, from the lowest: compounds 1, 2 and 3 (each within the scatter of the next).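

In this assay, 4-hydroxyphenyl in place of 2-(4-methoxyphenyl)ethyl on a saturated chain carbon bound to an amine nitrogen gives a 1.2-fold higher number from compound 2 to compound 3 (0.09 log units; within the scatter), so a hydrogen-bond donor entering at this place, together with the loss of the chain, leaves the number within the scatter. Hydroxy in place of chloro on an aromatic carbon gives a 1.3-fold higher number from compound 1 to compound 3 (0.10 log units; within the scatter), a change made on the ring alone with the chain held constant, and this too stays within the scatter. No supporting measurement bears on why these exchanges leave the number flat.

On these data alone, whether an amine or a carboxylic acid on that aromatic carbon, or a chain longer than 3-(4-methoxyphenyl)propyl, would step beyond the scatter remains open. Also open, as far as these compounds go, is whether any change to the shared core would move the number further than these amine-side exchanges.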